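Butyl to 4-methoxyphenyl on the amide of compound 1

This account rests on a few compounds, and the source may have more. Where it says the series, first, only, none or still open, it means among the compounds named here.

Compound 1 `CCCCCN1C(=O)C/C(=C\c2cccc(C(=O)NCCCC)c2)C1=O`: in an ADME assay on NCM460 cells (Homo sapiens) for cytotoxicity, read by MTT assay, with a stated time of 72 h (on this read-out higher numbers stand for weaker inhibition and lower numbers for stronger inhibition), compound 1 gives > 100000 nM, a limit of the assay rather than a number.
Compound 2 `O=C(Nc1ccccc1)c1cccc(/C=C2\CC(=O)N(c3ccccc3)C2=O)c1`: compound 2 gives > 100000 nM, again a limit.
Compound 3 `Cc1ccc(N2C(=O)C/C(=C\c3cccc(C(=O)Nc4ccc(Cl)cc4)c3)C2=O)cc1`: compound 3 gives > 100000 nM, also a limit.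

Compound 1 therefore stands where every measured compound stands: at the limit of > 100000 nM in this assay, at which 3 of the 3 values shown sit, so no order among the three can be read. Compound 4 `CCCCCN1C(=O)C/C(=C\c2cccc(C(=O)Nc3ccc(OC)cc3)c2)C1=O` differs from compound 1 by 4-methoxyphenyl in place of butyl on an amide-type nitrogen. Among the compounds with values here, no measured step exists for this change, and with all three values at the same limit, no step beyond the scatter is expected in this assay. For compound 4 the estimate is 100000 nM, ranging from 30000 nM to 300000 nM. The expected step of a number no higher from compound 1 to compound 4 (the limit leaves the size open) is thus none beyond the scatter.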

Compound 4, half-maximal inhibitory concentration: > 100000 nM
Compound 4: no number, only a limit; the forecaster's own chance of this, stated with the estimate: 85%; the middle value lies on the limit itself.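

In this assay, within the data shown here, compound 1 and compound 4 both stand at a limit rather than a number, so no step between them can be read. The compounds shown leave open whether 4-methoxyphenyl in place of butyl changes the read-out at all.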